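Swapping the Aryl Amine Substituent on a Urea Core

The source may hold more compounds than are shown below. What is called first, only, known or untested is meant among the compounds shown, and "the series" means these compounds.

Compound 1 `COc1cc(NC(=O)Nc2cc(Nc3ccc(F)c(Cl)c3)ncn2)cc(OC)c1` gives the higher of two measured numbers in a functional assay on NCI-H1581 cells (Homo sapiens) for inhibition, read by MTT assay, with a stated time of 48 h, tested at 10 uM; a lower number here means less inhibition, a higher number more inhibition at the concentration tested (going by the name of the read-out): compound 1 gives 53%, whereas compound 2 `CCc1ccc(Nc2cc(NC(=O)Nc3c(Cl)cccc3Cl)ncn2)cc1` gives 38.1%. Compound 3 `COc1cc(NC(=O)Nc2cc(Nc3ccc(OC)c(I)c3)ncn2)cc(OC)c1` keeps the core of compound 1 but carries 3-iodo-4-methoxyphenyl in place of 3-chloro-4-fluorophenyl on a nitrogen on an aromatic ring. Within the data shown here, no measured pair shows this kind of exchange, so nothing here tells how large its effect is. The step is expected to be small, not beyond the usual scatter in either direction, and the estimate is a number 3 percentage points lower from compound 1 to compound 3 (within the scatter). Compound 3 is thus expected to give about 50% in this assay, with a likely range from 30% to 70%.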

Compound 3, a percentage reported as inhibition, at one concentration (the size of the read-out at that concentration, not a potency): 43%
The estimate for compound 3 lay 7 percentage points above the measured number, within the range that was stated.
By their numbers in this assay, from the lowest: compounds 2, 3 and 1 (each within the scatter of the next, the first and the last beyond it).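

Among these compounds, this is the first measured exchange on the aryl amine nitrogen. Replacing 3-chloro-4-fluorophenyl with 3-iodo-4-methoxyphenyl gives a number 10 percentage points lower from compound 1 to compound 3 (within the scatter) in this assay, so this swap of both ring substituents together produces no change that can be told from the scatter. No supporting measurement explains this result.

Going by these compounds, since iodine and methoxy arrive together, the separate contribution of each remains open. It is also unknown whether an amine or a carboxylic acid on this phenyl ring would shift the reading beyond the scatter.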